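Swapping the aryl group on the triazole of a spiro-fused core

A few compounds are considered here, and "the series" means these few. Any claim that something is new, unique, unknown or untested is made for them only; others in the source may bear on it.

Of the compounds shown here, three sharing one elaborate spiro-fused core have been tested in a functional assay on HepG2 cells (Homo sapiens) for antiproliferative activity, read by MTT assay, with a stated time of 48 h (a lower number here means a stronger inhibitor, a higher number a weaker inhibitor), and all three differ only in the aromatic group attached to the triazole nitrogen. Compound 1 `N#CC1=C(N)Oc2c(c3nc4ccccc4nc3c3ccccc23)C12C(=O)N(Cc1cnnn1-c1ccc(Br)cc1)c1ccccc12` carries a 4-bromophenyl there. In this assay compound 1 reaches only the limit of the measurement, > 50000 nM. Compound 2 `Cc1ccc(C)c(-n2nncc2CN2C(=O)C3(C(C#N)=C(N)Oc4c3c3nc5ccccc5nc3c3ccccc43)c3ccccc32)c1` carries a 2,5-dimethylphenyl instead. In this assay compound 2 likewise reaches only the limit, > 50000 nM. Among the measured compounds shown here, the one step between these two, a step that the two limits leave unreadable from compound 1 to compound 2, therefore cannot be sized. Compound 3 `Cc1cccc(-n2nncc2CN2C(=O)C3(C(C#N)=C(N)Oc4c(N)cc5nc6ccccc6nc5c43)c3ccccc32)c1` carries a 3-methylphenyl and also bears an amino group on its core. In this assay compound 3 again reaches only the limit, > 50000 nM. For the measured compounds named here, because of the limit of > 50000 nM in this assay, at which 3 of the 3 values shown sit, compound 3 cannot be placed anywhere except at that limit, and no measured step has a readable size.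

Compound 4 `N#CC1=C(N)Oc2c(N)cc3nc4ccccc4nc3c2C12C(=O)N(Cc1cnnn1-c1cc(Cl)ccc1Cl)c1ccccc12` is the next variation on the same theme: 2,5-dichlorophenyl in place of 3-methylphenyl on an aromatic nitrogen. Going by the values given here, no measured step bears on this change in a readable way. The step from compound 3 to compound 4 is estimated as a number no higher from compound 3 to compound 4 (the limit leaves the size open). Compound 4 is expected to give about 50000 nM in this assay, within a range from 15000 nM to 200000 nM.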

Compound 4, half-maximal inhibitory concentration: 33100 nM
Beside the measured number, compound 4's estimate is 1.5-fold (0.18 log units) above it, within the range that was stated.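

In this assay, among the compounds shown here, compound 4 gives 33100 nM, the first value in this set that is a number and not a limit, so this position on the aromatic nitrogen can carry a group that brings a measurable result. Replacing 3-methylphenyl with 2,5-dichlorophenyl gives an at least 1.5-fold lower number from compound 3 to compound 4 (0.17 log units; that floor lies within the scatter), so the change is only weakly supported as a real gain, although the true step could be larger than this floor. From the compounds shown here alone, the remaining step in the set cannot be read, and the size of this one stays open because the comparison rests on a limit: the limit of > 50000 nM in this assay, at which 3 of the 4 values shown sit.

The compounds shown leave open whether both chlorine atoms contribute, since a phenyl ring with only one chlorine at either of these places would separate their roles, and a 2,5-dimethylphenyl on the core of compound 4 would show whether chlorine or just the placement of two groups goes with the measured value. They also leave open what happens with an amine or a carboxylic acid on the phenyl ring, or with a longer chain in place of that ring.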